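Swapping ethyl for cyclopropyl on the amide carbonyl

This account rests on a few compounds, and the source may have more. Where it says the series, first, only, none or still open, it means among the compounds named here.

Measured compounds:
Compound 1, `CCn1c(-c2cnc(C)nc2)nc2c(O[C@H]3CCN(C(=O)C4CC4)C3)ncnc21`: in an ADME assay (Canis lupus familiaris, strain Beagle) for pharmacokinetics (a lower number here means that more of the compound stays in the plasma, a higher number that more of the compound sits outside the plasma), compound 1 gives 0.6 L/kg.
Compound 2, `CCC(=O)N1CC[C@H](Oc2ncnc3c2nc(-c2cnc(C)nc2)n3CC)C1`: in this assay compound 2 gives 1.9 L/kg.
Compound 3, `CCC(=O)N1CC[C@H](Nc2ncnc3c2nc(-c2cnc(C)nc2)n3CC)C1`: in this assay compound 3 gives 1.5 L/kg.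

Compound 1 and compound 2 share a core and differ only at the amide: cyclopropyl in place of ethyl on a carbonyl carbon. That change gave a 3.2-fold lower number from compound 2 to compound 1 (0.50 log units; beyond the scatter). Compound 3 has a different core from compound 2; the difference between the two cores is not broken down here. In this assay compound 3 and compound 2 lie within the usual scatter of each other, while compound 3 sits beyond the scatter from compound 1.

Compound 4, `CCn1c(-c2cnc(C)nc2)nc2c(N[C@H]3CCN(C(=O)C4CC4)C3)ncnc21`, is still to be measured. It is made from compound 3 by cyclopropyl in place of ethyl on a carbonyl carbon, at a place described in the same words as for the step from compound 2 to compound 1. Because compound 2 to compound 1 gave a 3.2-fold lower number from compound 2 to compound 1 (0.50 log units; beyond the scatter), a step of similar size is expected here, estimated as a 2.7-fold lower number from compound 3 to compound 4 (0.44 log units; beyond the scatter). Compound 4 is therefore estimated at 0.55 L/kg, expected between 0.3 L/kg and 1.2 L/kg.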

Compound 4, volume of distribution: 1.5 L/kg
Beside the measured number, compound 4's estimate is 2.7-fold (0.44 log units) below it; the whole stated range lies below it.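

In this assay the change from ethyl to cyclopropyl on the carbonyl carbon gives no change at the digits printed from compound 3 to compound 4 (within the scatter) and so does not repeat the drop seen on the core of compound 2. The outcomes on the two cores differ by more than repeated measurements would normally explain: the same change on two cores in this assay, a 3.2-fold lower number (0.50 log units; beyond the scatter) from compound 2 to compound 1 and no change at the digits printed (within the scatter) from compound 3 to compound 4, 3.2-fold (0.50 log units) apart, beyond the scatter of two such steps. This shows that, in this series, the result of this change on one core is not a safe guide to its result on the other, but it does not show why the two cores differ, and one pair of compounds on each core gives no rule for any further core.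

The compounds shown leave open how a longer chain such as butanoyl, or an acyl group carrying an amine, would behave on the same carbonyl carbon of either core. They also leave open whether a third core would respond to cyclopropyl like the core of compound 2 or like the core of compound 3.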